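Benzyl in place of an aryl group on the amine nitrogen

The source may hold more compounds than are shown below. What is called first, only, known or untested is meant among the compounds shown, and "the series" means these compounds.

Working notes on the series. Compound 1 `O=C1C(Nc2ccc(I)cc2)=CC(=O)c2c1nc1n2[C@H]2OC[C@@H](O)[C@H]2OC1` is the reference point. In a functional assay on MCF7 cells (Homo sapiens) for inhibition, read by sulforhodamine B assay (on this read-out higher numbers stand for weaker inhibition and lower numbers for stronger inhibition), compound 1 gives 3890 nM, the lowest of the two numbers recorded so far; compound 2 `O=C1C=C(Nc2cccc(F)c2)C(=O)c2c1nc1n2[C@H]2OC[C@@H](O)[C@H]2OC1` gives 5500 nM in this assay, which lies within the scatter of compound 1, so no order between the two can be claimed. Compound 3 `CCCN(CCC)C1=CC(=O)c2nc3n(c2C1=O)[C@H]1OC[C@@H](O)[C@H]1OC3` is recorded in this assay only as > 16000 nM, a limit of the assay and not a number.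

Among the measured compounds shown here, the one measured step that bears on the change under study is an at least 2.9-fold higher number from compound 2 to compound 3 (0.46 log units; beyond the scatter), where an arylamino group gave way to a dialkylamino group and inhibition weakened by at least a modest amount. Compound 4 `O=C1C(NCc2ccccc2)=CC(=O)c2c1nc1n2[C@H]2OC[C@@H](O)[C@H]2OC1` differs from compound 1 by benzyl in place of 4-iodophenyl on an amine nitrogen. As in compound 3, the group on the amine nitrogen is no longer an aryl, so a weakening of similar, modest size is expected for compound 4, namely a 2.1-fold higher number from compound 1 to compound 4 (0.31 log units; beyond the scatter). The estimate for compound 4 in this assay is 8000 nM, with a range from 3000 nM to 20000 nM.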

Compound 4, half-maximal inhibitory concentration: > 8000 nM
Compound 4 ended at the assay's limit; the forecaster's own chance of this, stated with the estimate: 20%; the middle value lies on the limit itself.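

In this assay compound 4 gives > 8000 nM, which is a limit of the assay and not a number. Even so, the change reads as an at least 2.0-fold higher number from compound 1 to compound 4 (0.31 log units; beyond the scatter), so on this amine nitrogen benzyl does not match 4-iodophenyl, and the weakening does not require two alkyl chains on that nitrogen, as in the dipropylamino group of compound 3. The true size of the loss cannot be read because the record for compound 4 stops at a limit: the limit of > 8000 nM in this assay, at which 1 of the 4 values shown sits.

The change removes the iodine and moves the ring one carbon away from the nitrogen in a single step, so the compounds shown do not separate these two differences; a plain phenyl or a 4-iodobenzyl group would do so. From the compounds shown here alone, whether a longer chain such as 2-phenylethyl behaves as benzyl does also stays open.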